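This account rests on a few compounds, and the source may have more. Where it says the series, first, only, none or still open, it means among the compounds named here.

Measured so far:
compound 1, `Fc1ccc(N2N=NCC2c2ccncc2)cc1`, in this assay gives 239 mg/kg;
compound 2, `FC(F)(F)c1ccc(N2N=NCC2c2ccncc2)cc1`, gives 689 mg/kg;
compound 3, `FC(F)(F)c1ccc(-n2nncc2-c2cccnc2)cc1`, gives 92.3 mg/kg.

All three were tested in a functional assay on the whole organism with Mus musculus as the target, in the maximal electroshock model; on this read-out lower numbers stand for an effect already at smaller amounts and higher numbers for an effect only at larger amounts of compound. Compound 4, `Fc1ccc(-n2nncc2-c2cccnc2)cc1`, has not yet been measured there. Compound 4 differs from compound 3 by fluoro in place of trifluoromethyl on an aromatic carbon. The same change is already seen in a measured pair: compound 1 differs from compound 2 by fluoro in place of trifluoromethyl on an aromatic carbon, and in this assay that change gave a 2.9-fold lower number from compound 2 to compound 1 (0.46 log units; beyond the scatter). The core of compound 3 is not the core of compound 2, and the difference between the two cores is not broken down here. Among the measured compounds, compound 3 has the lowest number, with compound 1 nearer to it and compound 2 furthest away. A step of about the same size is expected for compound 4, namely a 2.6-fold lower number from compound 3 to compound 4 (0.42 log units; beyond the scatter), because the earlier step of a 2.9-fold lower number from compound 2 to compound 1 (0.46 log units; beyond the scatter) came from this very change at the same place. This rests on a single precedent on a different core, so the range is kept wide. For compound 4 the estimated value is 35 mg/kg, expected to fall between 15 mg/kg and 90 mg/kg.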

Compound 4, dose for half-maximal effect: 74.6 mg/kg
Compound 4: middle estimate off by 2.1-fold (0.33 log units), on the low side; the range from low to high includes it.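

In this assay, putting fluoro in place of trifluoromethyl gave a 1.2-fold lower number from compound 3 to compound 4 (0.09 log units; within the scatter), so on this core the swap makes no clear difference. Set beside the earlier step, this result does not separate the two cores, since the gap between the two steps is no larger than repeated measurements could produce: the same change on two cores in this assay, a 2.9-fold lower number (0.46 log units; beyond the scatter) from compound 2 to compound 1 and a 1.2-fold lower number (0.09 log units; within the scatter) from compound 3 to compound 4, 2.3-fold (0.37 log units) apart, within the scatter of two such steps. For the compounds shown here, this shows that the change behaves about the same on both cores within the precision of the assay, but it does not show a fixed step that can be carried to a further core, as only two pairs exist, one beyond the scatter and one within it.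

On these data alone, only fluoro and trifluoromethyl appear at this place on the aromatic ring, so the effect of a group such as a nitrile, a methoxy group or an amine there remains open. As far as these compounds go, whether a carboxylic acid or a longer chain at the same place would fit the same picture on either core also remains open.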